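Sulfur to Selenium Exchange Across Two Cores

This account rests on a few compounds, and the source may have more. Where it says the series, first, only, none or still open, it means among the compounds named here.

Measured compounds:
Compound 1 `COc1ccc(N(CC(=O)NCCCSc2ccccc2)C(=O)CCSC2=C(C)C(=O)c3ccccc3C2=O)cc1` gives 17000 nM in a functional assay on A-431 cells (Homo sapiens) for cytotoxicity, read by MTT assay, with a stated time of 24 h; on this read-out higher numbers stand for weaker inhibition and lower numbers for stronger inhibition.
Compound 2 `COc1ccc(N(CC(=O)NCCC[Se]c2ccccc2)C(=O)CCSC2=C(C)C(=O)c3ccccc3C2=O)cc1` gives 17000 nM in this assay.
Compound 3 `COc1ccc(N(CC(=O)NCCCSc2ccccc2)C(=O)/C=C/c2ccccc2)cc1` gives only a limit of the assay, >= 100000 nM, in this assay.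

Compound 1 and compound 2 share one core and differ in a single place: a group of 7 heavy atoms (6 carbon, 1 selenium; one six-membered aromatic ring of carbon only) in place of a group of 7 heavy atoms (6 carbon, 1 sulfur; one six-membered aromatic ring of carbon only), on a saturated chain carbon, three bonds along the chain from an amide-type nitrogen. The step of no change at the digits printed from compound 1 to compound 2 (within the scatter) shows that this exchange left the read-out where it was. Compound 3 has a different core; the difference between the two cores is not broken down here. For compound 3 the assay reports only a limit, marked by the limit of >= 100000 nM in this assay, at which 1 of the 3 values shown sits.

Compound 4 `COc1ccc(N(CC(=O)NCCC[Se]c2ccccc2)C(=O)/C=C/c2ccccc2)cc1` has not yet been measured in this assay. It stands to compound 3 as compound 2 stands to compound 1, with the same change at the same place: a group of 7 heavy atoms (6 carbon, 1 selenium; one six-membered aromatic ring of carbon only) in place of a group of 7 heavy atoms (6 carbon, 1 sulfur; one six-membered aromatic ring of carbon only), on a saturated chain carbon, three bonds along the chain from an amide-type nitrogen. Within the data shown here, since the exchange on the first core produced no change at the digits printed from compound 1 to compound 2 (within the scatter), compound 4 is expected to show a step of about a number no higher from compound 3 to compound 4 (the limit leaves the size open) from compound 3, again essentially no change. Compound 4 is therefore estimated at 100000 nM, with a range of 50000 nM to 300000 nM, most likely reported again only as a limit.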

Compound 4, half-maximal inhibitory concentration: >= 100000 nM
Compound 4: no number, only a limit; the forecaster's own chance of this, stated with the estimate: 85%; the middle value sits exactly at the limit.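

In this assay compound 4 gives >= 100000 nM, a limit of the assay and not a number. Among these compounds, compound 3 gives >= 100000 nM, also a limit, so no step from compound 3 to compound 4 can be read. The compounds shown leave open whether selenium in place of sulfur changes the read-out on the core of compound 3, as both compounds rest at one limit: the limit of >= 100000 nM in this assay, at which 2 of the 4 values shown sit.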